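Methyl for cyclopropyl on the thiazole of compound 3

This account rests on a few compounds, and the source may have more. Where it says the series, first, only, none or still open, it means among the compounds named here.

Compound 1 `CC1CCN(C2CCN(S(=O)(=O)c3cccc(Br)c3)CC2)CC1` carries 3-bromophenyl on the sulfonyl sulfur; in a functional assay on DLD-1 cells (Homo sapiens) for antiproliferative activity, read by CellTiter-Glo, with a stated time of 72 h (on this read-out higher numbers stand for weaker inhibition and lower numbers for stronger inhibition), compound 1 gives 3.2 nM. Compound 2 `Cc1noc(C)c1S(=O)(=O)N1CCC(N2CCC(C)CC2)CC1` carries 3,5-dimethyl-1,2-oxazol-4-yl at the same sulfur; in this assay compound 2 returns only the limit > 5000 nM. The change is an at least 1500-fold higher number from compound 1 to compound 2 (3.19 log units; beyond the scatter). Compound 3 `CC1CCN(C2CCN(S(=O)(=O)c3sc(Cl)nc3C3CC3)CC2)CC1` carries the chloro-thiazolyl with a cyclopropyl; in this assay compound 3 likewise returns only the limit > 5000 nM. Compound 3 therefore stands at the limit of > 5000 nM in this assay, at which 2 of the 3 values shown sit, and only compound 1 has a numbered value.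

Within the data shown here, compound 4 `Cc1nc(Cl)sc1S(=O)(=O)N1CCC(N2CCC(C)CC2)CC1` differs from compound 3 in one place: methyl in place of cyclopropyl on an aromatic carbon The single measured step concerns the whole aryl group on the sulfonyl sulfur, not a substituent on a retained ring, so no measured step bears directly on this change. With compound 3 already at the limit, a small substituent swap on the same ring gives no ground to expect a reading that moves off it. Compound 4 is expected to sit at or near the limit as well, estimated at 6000 nM with a range of 1500 nM to 25000 nM. The expected step is a step that the limit leaves unreadable from compound 3 to compound 4, not beyond the scatter.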

Compound 4, half-maximal inhibitory concentration: 1.6 nM
Estimate against measurement, compound 4: 3800-fold (3.57 log units) above; the measured number lies below the stated range.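

On the 2-chloro-4-methyl-1,3-thiazol-5-yl series, the substituent on the aromatic carbon next to the ring nitrogen alone switches the read-out in this assay: methyl in place of cyclopropyl gives an at least 3100-fold lower number from compound 3 to compound 4 (3.49 log units; beyond the scatter). The earlier step covered only the exchange of a whole aryl group on the sulfonyl sulfur, whereas an at least 3100-fold lower number from compound 2 to compound 4 (3.49 log units; beyond the scatter) now shows that a five-membered aromatic ring on that sulfur is compatible with a low number. Against the 3-bromophenyl group, the 2-chloro-4-methyl-1,3-thiazol-5-yl group gives a 2.0-fold lower number from compound 1 to compound 4 (0.30 log units; within the scatter), so no order can be drawn between the two.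

From the compounds shown here alone, the true size of the two steps starting from limit values stays unknown, since those starting values are limits and not numbers: the limit of > 5000 nM in this assay, at which 2 of the 4 values shown sit. Still open is whether ethyl, methoxy or an amino group on this carbon would read like methyl or like cyclopropyl, and whether the chloro group is needed for the reading of compound 4.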